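The source may report more compounds than this note shows. Statements on the series, on what has been measured and on what is new or still open speak of the compounds shown alone.

In a functional assay on MDA-MB-231 cells (Homo sapiens) for cytotoxicity, read by MTT assay, with a stated time of 72 h (a lower number here means a stronger inhibitor, a higher number a weaker inhibitor), compound 2 `O=C(CN1CCN(c2nnc(Cc3ccncc3)c3ccccc23)CC1)Nc1cccc(F)c1` gives 4.4 nM, the lowest of the two numbers recorded so far. Compound 1 `O=C(CN1CCN(c2nnc(Cc3ccccc3)c3ccccc23)CC1)Nc1c(F)cccc1F` differs from compound 2 in two places at once. In this assay compound 1 gives 5490 nM, a gap far beyond the scatter. Among the compounds with values here, the two measured compounds differ in more than one place, so no single step between them can be read. Within the data shown here, the two values show only that this pair lies far apart.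

Compound 3 `O=C(CN1CCN(c2nnc(Cc3ccncc3)c3ccccc23)CC1)Nc1c(F)cccc1F` has not yet been measured in this assay. It differs from compound 2 in one place: 2,6-difluorophenyl in place of 3-fluorophenyl on an amide-type nitrogen. Among the measured compounds shown here, the group that enters is the one carried by compound 1, while the rest of compound 3 matches compound 2. Compound 1 gives 5490 nM with this same 2,6-difluorophenyl in place, though its other difference from compound 2 leaves the share of this change alone unknown. On that basis a move towards a higher number, likely beyond the scatter, is expected, a 14-fold higher number from compound 2 to compound 3 (1.13 log units; beyond the scatter). In this assay compound 3 is estimated at 60 nM, within a deliberately wide range from 5 nM to 800 nM.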

Compound 3, half-maximal inhibitory concentration: 1900 nM
Beside the measured number, compound 3's estimate is 32-fold (1.50 log units) below it; the measured number lies above the stated range.
By their numbers in this assay, from the lowest: compound 2; then compound 3; then compound 1.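

In this assay, the group on the amide-type nitrogen now has a step of its own: 2,6-difluorophenyl in place of 3-fluorophenyl gives a 430-fold higher number from compound 2 to compound 3 (2.64 log units; beyond the scatter), with the rest of the structure unchanged. The other single change, pyridin-4-yl in place of phenyl on a saturated chain carbon bound to an aromatic carbon, gives a 2.9-fold lower number from compound 1 to compound 3 (0.46 log units; beyond the scatter), so with 2,6-difluorophenyl in place this change moves the number much less than the change on the amide-type nitrogen does. The earlier pair could not divide its gap between the two places, whereas these steps put the larger share on the amide-type nitrogen. Nothing available explains either step.

On these data alone, it remains open whether pyridin-4-yl in place of phenyl would give a step of similar size with 3-fluorophenyl on the amide-type nitrogen, so the two changes cannot yet be called independent of each other. As far as these compounds go, it is also open how an unsubstituted phenyl or a cyclohexyl on that nitrogen would read in this assay.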